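The source may report more compounds than this note shows. Statements on the series, on what has been measured and on what is new or still open speak of the compounds shown alone.

Of the compounds shown here, two have been measured in a functional assay on the whole organism (serum, strain Swiss albino) with Rattus norvegicus as the target, read by spectrophotometry, with a stated time of 14 days, at a dose of 10 mg/kg by the oral route; on this read-out lower numbers stand for less inhibition and higher numbers for more inhibition at the one dose given (going by the name of the read-out). Compound 1, with structure `O=C1c2c(Cl)c(Cl)c(Cl)c(Cl)c2C(=O)N1c1ccncc1`, carries four chlorine atoms on its core and a pyridin-4-yl group on the ring nitrogen; in this assay compound 1 gives 44%, the higher of the two numbers recorded so far. Compound 2, with structure `O=C1c2cc(Cl)c(Cl)cc2C(=O)N1c1ccccn1`, carries two chlorine atoms and a pyridin-2-yl group; in this assay compound 2 gives 17%, a gap from compound 1 that lies beyond the usual scatter. Compound 2 differs from compound 1 in more than one place. Within the data shown here, no single step can be drawn between them.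

Compound 3, with structure `O=C1c2c(Cl)c(Cl)c(Cl)c(Cl)c2C(=O)N1c1ccccn1`, keeps the four chlorine atoms of compound 1 and changes only the group on the ring nitrogen: pyridin-2-yl in place of pyridin-4-yl on an amide-type nitrogen in a ring

Among the measured compounds shown here, no measured pair isolates this change. For the measured compounds named here, compound 2, the only measured compound with pyridin-2-yl, sits low at 17%, so a modest decrease is expected from compound 1 to compound 3, though possibly within the scatter: a number 9 percentage points lower from compound 1 to compound 3 (within the scatter). Compound 3 is therefore estimated to give 35% in this assay, with a likely range from 20% to 50%.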

Compound 3, a percentage reported as inhibition, in the whole organism at one dose (the size of the read-out at that dose, not a potency): 9%
For compound 3 the middle estimate is 26 percentage points above the measured one, and the stated range ends above it.
By their numbers in this assay, from the lowest: compounds 3 and 2 (each within the scatter of the next); then compound 1.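

In this assay, placing pyridin-2-yl in place of pyridin-4-yl on an amide-type nitrogen in a ring gives a number 35 percentage points lower from compound 1 to compound 3 (beyond the scatter) with the four chlorine atoms of the core unchanged. Among these compounds, this is the first comparison in the set that isolates a single place, and it shows that the read-out at this position is sensitive to this change: the two groups have the same heavy atoms and the same counts of hydrogen-bond donors and acceptors, so the large step goes with how those atoms are joined and not with any difference in those counts. Nothing available accounts for the size of the step.

The compounds shown leave open whether the same step would appear on the core of compound 2, with its two chlorine atoms, as pyridin-4-yl appears here only with four chlorine atoms on the core. They also leave open what pyridin-3-yl, a plain phenyl ring or a ring carrying an amine or a carboxylic acid would give on the same nitrogen.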